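The source may hold more compounds than are shown below. What is called first, only, known or untested is meant among the compounds shown, and "the series" means these compounds.

Working notes on the series. For the measured compounds named here, in a functional assay on GTL 16 cells for antiproliferative activity against GTL 16 cell line (Homo sapiens), read by CCK-8 assay, with a stated time of 72 h (on this read-out higher numbers stand for weaker inhibition and lower numbers for stronger inhibition), compound 2 `Cc1ccc(C(=O)Nc2cccc(-c3oc4cc(-c5ccc(F)cc5)ccc4c(=O)c3O)c2)cc1` gives 12900 nM, the lower of only two numbers so far. Compound 1 `COc1ccc(C(=O)Nc2cccc(-c3oc4cc(-c5ccc(F)cc5)ccc4c(=O)c3O)c2)cc1` gives 21100 nM in this assay, and a 1.6-fold lower number from compound 1 to compound 2 (0.21 log units; within the scatter) stays within the scatter. Compound 3 `O=C(Nc1cccc(-c2oc3cc(-c4ccc(F)cc4)ccc3c(=O)c2O)c1)c1ccc(F)cc1F` carries 2,4-difluorophenyl in place of 4-methylphenyl on a carbonyl carbon. Going by the values given here, no measured step bears directly on this exchange; the single step available, methoxy to methyl, did not move the number beyond the scatter, and nothing here speaks for a larger effect. The expected step is therefore a 1.1-fold lower number from compound 2 to compound 3 (0.03 log units; within the scatter), none beyond the scatter. Compound 3 is estimated at 12000 nM, with a range of 4000 nM to 40000 nM.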

Compound 3, half-maximal inhibitory concentration: 9640 nM
For compound 3 the middle estimate is 1.2-fold (0.10 log units) above the measured one; the range from low to high includes it.
By their numbers in this assay, from the lowest: compounds 3, 2 and 1 (each within the scatter of the next, the first and the last beyond it).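

In this assay, 2,4-difluorophenyl on a carbonyl carbon whose other neighbour is the amide-type nitrogen takes the place of 4-methylphenyl with a 1.3-fold lower number from compound 2 to compound 3 (0.13 log units; within the scatter) and no real shift. Against the 4-methoxyphenyl amide, the same group gives a 2.2-fold lower number from compound 1 to compound 3 (0.34 log units; beyond the scatter) as the first step in the series beyond the scatter, though only a modest one. No measurement available explains either step.

Still open, as far as these compounds go, is whether an amine or a carboxylic acid on this phenyl ring would move the number further. Also open, from the compounds shown here alone, is whether replacing the ring with a longer alkyl chain would keep the activity.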